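Removing a Methyl from a Ring Oxygen: Compound 4 Expected

This account rests on a few compounds, and the source may have more. Where it says the series, first, only, none or still open, it means among the compounds named here.

Compound 2 `COc1cc2c(c(OC)c1OC)c(=O)ccn2C` carries methyl on each of its ring oxygens. In a functional assay on HL-60 cells (Homo sapiens) for antiproliferative activity (a lower number here means a stronger inhibitor, a higher number a weaker inhibitor), compound 2 gives > 30000 nM, which is a limit of the assay rather than a number. Compound 1 `COc1cc2c(c(O)c1OC)c(=O)ccn2C` differs from it by hydrogen in place of methyl on an oxygen on an aromatic ring. In this assay compound 1 gives > 30000 nM, again only a limit. The step that the two limits leave unreadable from compound 2 to compound 1 therefore cannot be sized from these two values. Compound 3 `COc1cc(C(F)(F)F)cc2nccc(O)c12` has another core; how it differs from compound 2 is not broken down here. In this assay compound 3 gives > 30000 nM, once more a limit, in keeping with the limit of > 30000 nM in this assay, at which 3 of the 3 values shown sit. Compound 4 `Oc1ccnc2cc(C(F)(F)F)cc(O)c12` arises from compound 3 by hydrogen in place of methyl on an oxygen on an aromatic ring, the same change as from compound 2 to compound 1. Compound 4 is expected to move by a step that the limit leaves unreadable from compound 3 to compound 4. In this assay compound 4 is estimated at 40000 nM, most likely reported again as a limit.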

Compound 4, half-maximal inhibitory concentration: > 30000 nM
Compound 4: only a limit was reported (the forecaster's own chance of this, stated with the estimate: 85%); the middle value does not contradict the limit.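

Going by these compounds alone, the values of compound 3 and compound 4 are both limits of the assay, so no step between them can be read. The compounds shown leave open whether methoxy to hydroxy changes antiproliferative activity at all: the limit of > 30000 nM in this assay, at which 4 of the 4 values shown sit.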